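The source may hold more compounds than are shown below. What is called first, only, known or untested is meant among the compounds shown, and "the series" means these compounds.

Working notes on the series. In an assay on CHO-K1 cells for displacement of a labelled ligand from melanin-concentrating hormone receptor 1 (Homo sapiens), with a stated time of 2 h (on this read-out lower numbers stand for stronger inhibition and higher numbers for weaker inhibition), compound 1 `Cc1nc(N2CCC(O)CC2)nc2ccc(NC(=O)COc3ccc(Cl)cc3)cc12` gives 150 nM, while compound 2 `Cc1nc(N2CCN(CC(C)(C)C)CC2)nc2ccc(NC(=O)COc3ccc(Cl)cc3)cc12` gives 782 nM. Among the measured compounds shown here, compound 1 holds the lower of the two numbers recorded so far; its only neighbour is compound 2, reached by the step of a 5.2-fold higher number from compound 1 to compound 2 (0.72 log units; beyond the scatter), in which the ring on the aromatic carbon and the group it carries were both exchanged.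

Compound 3 `Cc1nc(N2CCC(C(=O)NC(C)C)CC2)nc2ccc(NC(=O)COc3ccc(Cl)cc3)cc12` is not yet measured in this assay. It differs from compound 1 by isopropylcarbamoyl in place of hydroxy on a saturated ring carbon. For the measured compounds named here, only one measured step bears on this, and loosely: from compound 1 to compound 2 the ring itself changed together with its substituent and the number rose, as the step of a 5.2-fold higher number from compound 1 to compound 2 (0.72 log units; beyond the scatter) records, whereas compound 3 keeps the ring of compound 1 and replaces the hydroxy alone with a larger group. A rise in the number is therefore expected in this assay, but a smaller one than that step. The estimate for compound 3 corresponds to a 2.3-fold higher number from compound 1 to compound 3 (0.37 log units; beyond the scatter). Compound 3 is expected to give 350 nM, with a range from 120 nM to 1000 nM.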

Compound 3, half-maximal inhibitory concentration: 15 nM
Compound 3: middle estimate off by 23-fold (1.37 log units), on the high side; measured number below the stated range.
By their numbers in this assay, from the lowest: compound 3; then compound 1; then compound 2.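

In this assay, the saturated ring carbon three ring bonds from the ring nitrogen takes a much larger group than hydroxy with a gain rather than a loss: with isopropylcarbamoyl in place of hydroxy, the record shows a 10-fold lower number from compound 1 to compound 3 (1.00 log units; beyond the scatter). The heavy-atom count of the group rises from 1 to 6 while its counted hydrogen-bond donor and acceptor stay the same, so the rise in a 5.2-fold higher number from compound 1 to compound 2 (0.72 log units; beyond the scatter), where the ring changed as well, does not carry over to a larger group on the ring of compound 1. No measurement given here accounts for the drop in the number from compound 1 to compound 3.

On these data alone, it remains open which part of isopropylcarbamoyl goes with this step, the carbonyl, the amide hydrogen or the isopropyl, and a primary carboxamide, a methyl ester or a carboxylic acid on the same carbon would separate these parts. Also open, as far as these compounds go, is whether a longer chain or a cyclohexyl group on the amide nitrogen lowers the number further.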